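The compounds below may be only part of what the source reports. "The series", "measured", "known", "first", "only" and "open" are said of these compounds alone.

Of the compounds shown here, three built on one shared core have so far been tested in a functional assay on MIA PaCa-2 cells (Homo sapiens) for inhibition, read by MTT assay, with a stated time of 48 h, tested at 10 uM; on this read-out higher numbers stand for more inhibition of growth at the one concentration tested and lower numbers for less inhibition of growth. Compound 1 `O=C(/C=C/c1ccc(OCc2cn(Cc3ccccc3Br)nn2)cc1)c1ccc([N+](=O)[O-])cc1` gives 34%. Compound 2 `O=C(/C=C/c1ccc(OCc2cn(Cc3ccccc3F)nn2)cc1)c1ccc([N+](=O)[O-])cc1` gives 22%. Compound 3 `O=C(/C=C/c1ccc(OCc2cn(Cc3cccc(F)c3)nn2)cc1)c1ccc([N+](=O)[O-])cc1` gives 32%, which places compound 3 second among the three numbers, with compound 1 its nearest neighbour and compound 2 its furthest. Between these, the exchange of bromo for fluoro gives a number 12 percentage points lower from compound 1 to compound 2 (beyond the scatter), the only step here beyond the scatter. The change of 2-bromophenyl to 3-fluorophenyl gives a number 2 percentage points lower from compound 1 to compound 3 (within the scatter), and the change of 2-fluorophenyl to 3-fluorophenyl gives a number 10 percentage points higher from compound 2 to compound 3 (within the scatter).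

Compound 4 `O=C(/C=C/c1ccc(OCc2cn(Cc3ccc(F)cc3)nn2)cc1)c1ccc([N+](=O)[O-])cc1` differs from compound 3 by 4-fluorophenyl in place of 3-fluorophenyl on a saturated chain carbon bound to an aromatic nitrogen. Among the measured compounds shown here, the step that bears on this most is the move of the fluorine within the same ring, a number 10 percentage points higher from compound 2 to compound 3 (within the scatter), which stayed within the scatter; no measured step covers the new position itself, so no shift beyond the scatter is expected. The expected step in this assay is a number 2 percentage points lower from compound 3 to compound 4 (within the scatter). Compound 4 is therefore estimated at 30%, within a range from 18% to 42%.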

Compound 4, percent growth inhibition at one concentration: 44%
Compound 4: the middle estimate sits 14 percentage points below what was measured; the measured number lies above the stated range.
By their numbers in this assay, from the lowest: compounds 2, 3, 1 and 4 (each within the scatter of the next, the first and the last beyond it).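

Among the three fluorine compounds, which have the same atoms joined differently, the place of the fluorine on the ring now matters in this assay. The change to 4-fluorophenyl from 3-fluorophenyl gives a number 12 percentage points higher from compound 3 to compound 4 (beyond the scatter), and the change to 4-fluorophenyl from 2-fluorophenyl gives a number 22 percentage points higher from compound 2 to compound 4 (beyond the scatter), the largest step in the set so far, whereas the earlier move from 2-fluorophenyl to 3-fluorophenyl stayed within the scatter. The change to 4-fluorophenyl from 2-bromophenyl gives a number 10 percentage points higher from compound 1 to compound 4 (within the scatter), so compound 4 does not stand clear of compound 1.

Nothing available here explains why 4-fluorophenyl differs from the other two fluorophenyl groups. Going by these compounds, whether 4-bromophenyl or 4-aminophenyl on the same saturated chain carbon would match compound 4 stays open, as does the effect of a longer chain in place of that single carbon.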